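A few compounds are considered here, and "the series" means these few. Any claim that something is new, unique, unknown or untested is made for them only; others in the source may bear on it.

In an ADME assay on Hepa-1c1c7 cells (Mus musculus) for cytotoxicity (on this read-out higher numbers stand for weaker inhibition and lower numbers for stronger inhibition), compound 3 `CCCCCCCCCC(O)C#CC#C[C@H](O)[C@H](C)O` gives 64200 nM, level within the scatter with compound 1 `CCCCCCCCCC(O)C#CC#C[C@@H](O)[C@H](C)O` at 39800 nM. That stereocentre step, a 1.6-fold higher number from compound 1 to compound 3 (0.21 log units; within the scatter), is small. Compound 2 `CCCCCC(O)C#CC#C[C@@H](O)[C@H](C)O` reaches only a limit, > 500000 nM. Compound 4 `CCCCCC(O)C#CC#C[C@H](O)[C@H](C)O` differs from compound 3 by hydrogen in place of butyl on a saturated chain carbon, six bonds along the chain from an oxygen on a saturated carbon and a triple-bonded carbon, with hydrogen in place of butyl on a saturated chain carbon. As far as these compounds go, the same change has been measured once, as an at least 12-fold higher number from compound 1 to compound 2 (1.09 log units; beyond the scatter), a large step whose true size remains open given (the limit of > 500000 nM in this assay, at which 1 of the 3 values shown sits). A similarly large rise is therefore expected here, the estimated step being an 11-fold higher number from compound 3 to compound 4 (1.04 log units; beyond the scatter). Compound 4 is estimated at 700000 nM, within a range of 300000 nM to 2000000 nM, and the assay may well return only a limit.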

Compound 4, half-maximal inhibitory concentration: > 500000 nM
Compound 4 was reported as a limit; the forecaster's own chance of this, stated with the estimate: 80%; the middle value does not contradict the limit.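

In this assay, the change from butyl to hydrogen on this saturated chain carbon gives an at least 7.7-fold higher number from compound 3 to compound 4 (0.89 log units; beyond the scatter), so the large rise is no longer confined to one configuration at the stereocentre. For compound 4, > 500000 nM is a limit of the assay and not a number. The step between compound 2 and compound 4 cannot be read, since both sit at the limit: the limit of > 500000 nM in this assay, at which 2 of the 4 values shown sit.

As far as these compounds go, how far the two butyl steps truly reach, and whether they differ, stays open: the same change on two cores in this assay, an at least 12-fold higher number (1.09 log units; beyond the scatter) from compound 1 to compound 2 and an at least 7.7-fold higher number (0.89 log units; beyond the scatter) from compound 3 to compound 4; the limit leaves it open whether they differ. From the compounds shown here alone, whether a longer chain at this carbon would lower the number further also remains open.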